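Cyclobutyl for Ethyl on the Chloro Analogue

The source may hold more compounds than are shown below. What is called first, only, known or untested is meant among the compounds shown, and "the series" means these compounds.

For the measured compounds named here, compound 3 `CCC(=O)N1N=C(c2cc(Cl)ccc2N)SC1(C)C` gives 1.07% in an assay on isolated protein for inhibition of Nitric oxide synthase, inducible (Homo sapiens), read by scintillation counting, with a stated time of 30 min, tested at 50 uM (a higher number here means more inhibition at the concentration tested (going by the name of the read-out), a lower number less inhibition), the lowest of the three numbers measured so far. Compound 1 `CCC(=O)N1N=C(c2cc(OC)ccc2N)SC1(C)C` gives 73% and compound 2 `COc1ccc(N)c(C2=NN(C(=O)C3CC3)C(C)(C)S2)c1` gives 90.1%; the step of a number 71.9 percentage points lower from compound 1 to compound 3 (beyond the scatter) shows how far the number for the chloro compound falls behind. Compound 4 `CC1(C)SC(c2cc(Cl)ccc2N)=NN1C(=O)C1CCC1` differs from compound 3 by cyclobutyl in place of ethyl on a carbonyl carbon. Going by the values given here, the only measured step that bears on this change is a number 17.1 percentage points higher from compound 1 to compound 2 (beyond the scatter), cyclopropyl in place of ethyl on a carbonyl carbon, a modest gain. A rise of about that size is therefore expected for the step of a number 10.9 percentage points higher from compound 3 to compound 4 (beyond the scatter), the very low starting number leaving little room beneath it. Compound 4 is accordingly estimated at 12%, within a range of 0% to 35%.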

Compound 4, a percentage reported as inhibition, at one concentration (the size of the read-out at that concentration, not a potency): -4.65%
The estimate for compound 4 lay 16.7 percentage points above the measured number; the whole stated range lies above it.
By their numbers in this assay, from the lowest: compounds 4 and 3 (each within the scatter of the next); then compound 1; then compound 2.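

In this assay, the chloro compounds show a number 5.7 percentage points lower from compound 3 to compound 4 (within the scatter), so cyclobutyl in place of ethyl on a carbonyl carbon leaves the number where it was, unlike the methoxy pair with cyclopropyl, a number 17.1 percentage points higher from compound 1 to compound 2 (beyond the scatter). Those two steps differ in both the entering group and the aromatic substituent, so the data cannot say which of these separates them. Nothing measured here accounts for the result. The compounds shown leave open how cyclobutyl would read with methoxy, and cyclopropyl with chloro. They also leave open how a longer chain or an amine on the carbonyl carbon would read.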